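Swapping Methyl for Chloro on the Furan Ring

The source may report more compounds than this note shows. Statements on the series, on what has been measured and on what is new or still open speak of the compounds shown alone.

Measured so far in a functional assay on A-431 cells (Homo sapiens) for inhibition, read by MTT assay, with a stated time of 72 h; on this read-out lower numbers stand for stronger inhibition of growth and higher numbers for weaker inhibition of growth:
- compound 1, `COc1ccc(CNC(=O)/C(C#N)=C/c2ccc[nH]2)cc1`: > 50000 nM, a limit of the assay rather than a number
- compound 2, `COc1ccc(CNC(=O)/C(C#N)=C/c2ccco2)cc1`: 16000 nM
- compound 3, `COc1ccc(CNC(=O)/C(C#N)=C/c2ccc(C)o2)cc1`: 58000 nM

Compound 3 gives the highest of the two numbers shown; the nearest is compound 2, and the step of a 3.6-fold higher number from compound 2 to compound 3 (0.56 log units; beyond the scatter) came with methyl in place of hydrogen on an aromatic carbon. The step of an at least 3.1-fold lower number from compound 1 to compound 2 (0.49 log units; beyond the scatter) exchanged one five-membered ring for another, and the step that the limit leaves unreadable from compound 1 to compound 3 cannot be sized because compound 1 sits at the limit (the limit of > 50000 nM in this assay, at which 1 of the 3 values shown sits).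

Compound 4, `COc1ccc(CNC(=O)/C(C#N)=C/c2ccc(Cl)o2)cc1`, differs from compound 3 by chloro in place of methyl on an aromatic carbon. Going by the values given here, none of the measured steps exchanges methyl for chloro, so no step bears directly on it; the closest guide is compound 3 itself at 58000 nM. In this assay compound 4 is therefore expected to stay near compound 3, with a step of a 1.5-fold lower number from compound 3 to compound 4 (0.16 log units; within the scatter), and the estimate for compound 4 is 40000 nM, within the range 10000 nM to 150000 nM.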

Compound 4, concentration for 50% growth inhibition: 9000 nM
Compound 4: the middle estimate sits 4.4-fold (0.65 log units) above what was measured; measured number outside the range, below it.
By their numbers in this assay, from the lowest: compounds 4 and 2 (each within the scatter of the next); then compound 3.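

In this assay, this aromatic carbon next to the ring oxygen does not treat methyl and chloro alike, although each is a single heavy atom: the exchange gives a 6.4-fold lower number from compound 3 to compound 4 (0.81 log units; beyond the scatter). Chloro in place of hydrogen gives a 1.8-fold lower number from compound 2 to compound 4 (0.25 log units; within the scatter), so of the two groups shown at this position, only methyl moves the number beyond the scatter. Compound 1 holds a limit rather than a number, and the step of an at least 5.5-fold lower number from compound 1 to compound 4 (0.74 log units; beyond the scatter) is bounded by it: the limit of > 50000 nM in this assay, at which 1 of the 4 values shown sits.

The compounds shown leave open how bromo, an amine or a longer chain would read on this same carbon. They also leave open whether chloro would give a similar result on the 1H-pyrrol-2-yl ring of compound 1.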